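This account rests on a few compounds, and the source may have more. Where it says the series, first, only, none or still open, it means among the compounds named here.

Three compounds have been measured for their largest response in an assay on CHO cells for agonist activity at Neuronal acetylcholine receptor; alpha3/alpha6/beta2/beta3 (Homo sapiens), read by FLIPR and calcium flux; on this read-out higher numbers stand for larger maximal responses and lower numbers for smaller maximal responses:

compound 1 `O=C(C1CC=CC1)N1CC2CC(C1)N2`: 99% in this assay
compound 2 `O=C(CC1C=CCC1)N1CC2CC(C1)N2`: 47% in this assay
compound 3 `O=C([C@@H]1C[C@@H]1F)N1CC2CC(C1)N2`: 120% in this assay

Among these three numbers compound 3 stands highest. Its nearest neighbour is compound 1, whose value lies lower by a gap beyond the usual scatter, and compound 2 lies furthest away, also beyond the scatter. Going by the values given here, no pair of measured compounds differs in a single place, so no single step can be read from the data.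

Compound 4 `C[C@H]1C[C@@H]1C(=O)N1CC2CC(C1)N2` has not yet been measured. It differs from compound 3 in one place: 2-methylcyclopropyl in place of 2-fluorocyclopropyl on a carbonyl carbon. Among the compounds with values here, the measured compounds contain no example of this exchange, so there is no direct guide to its size. The closest point of reference is compound 3 itself, which gives 120% in this assay. Given that a small ring on the carbonyl carbon is kept, only a small step is expected in this assay, most likely slightly downward or none beyond the scatter.

Compound 4 is therefore expected to give 105% in this assay, within a range from 80% to 130%. This estimate corresponds to an expected step of a number 15 percentage points lower from compound 3 to compound 4 (beyond the scatter).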

Compound 4, largest response reached (Emax), in percent of the reference or control that the assay uses: 64%
Beside the measured number, compound 4's estimate is 41 percentage points above it, and the stated range ends above it.
By their numbers in this assay, from the lowest: compound 2; then compound 4; then compound 1; then compound 3.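

In this assay, going by these compounds alone, 2-methylcyclopropyl in place of 2-fluorocyclopropyl on a carbonyl carbon gives a number 56 percentage points lower from compound 3 to compound 4 (beyond the scatter), the first single-place comparison in this set and a large one. The two groups have the same number of heavy atoms, the same three-membered ring, no hydrogen-bond donors or acceptors and two defined stereocentres each, so these counts do not separate them. At this position, then, keeping the small ring does not by itself keep the maximal response, and exchanging fluorine for a carbon atom is enough to change it markedly.

No available measurement gives a reason for the size of this step. As far as these compounds go, it also remains open where unsubstituted cyclopropyl or 2-chlorocyclopropyl would fall relative to compound 3 and compound 4, and whether another stereochemical arrangement of either group would give the same step.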